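Working notes: compound 3 to compound 4

A few compounds are considered here, and "the series" means these few. Any claim that something is new, unique, unknown or untested is made for them only; others in the source may bear on it.

Among the measured compounds shown here, the series so far holds compound 1 `O=C(CCSc1ccc2c(/C=C/c3ccccn3)n[nH]c2c1)Nc1cccc(C(F)(F)F)c1`, compound 2 `Cc1ccc(NC(=O)CCSc2ccc3c(/C=C/c4ccccn4)n[nH]c3c2)cc1C(F)(F)F` and compound 3 `CN(C)CCN(C)Cc1ccc(NC(=O)CCSc2ccc3c(/C=C/c4ccccn4)n[nH]c3c2)cc1C(F)(F)F`, all read in an ADME assay on BaF3 cells (Mus musculus) for antiproliferative activity, read by CCK-8 assay, with a stated time of 72 h; on this read-out higher numbers stand for weaker inhibition of growth and lower numbers for stronger inhibition of growth. Compound 1 gives 2300 nM, compound 2 gives 530 nM and compound 3 gives 1850 nM. Compound 3 is level with compound 1 within the scatter, and its number is higher than that of compound 2.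

The next analogue is compound 4 `Cc1cn(Cc2ccc(NC(=O)CCSc3ccc4c(/C=C/c5ccccn5)n[nH]c4c3)cc2C(F)(F)F)cn1`, with this change: 4-methyl-1H-imidazol-1-yl in place of (2-(dimethylamino)ethyl)(methyl)amino on a saturated chain carbon bound to an aromatic carbon. In words, 4-methyl-1H-imidazol-1-yl takes the place of (2-(dimethylamino)ethyl)(methyl)amino on a saturated chain carbon bound to an aromatic carbon.

The most relevant measurement is a 3.5-fold higher number from compound 2 to compound 3 (0.54 log units; beyond the scatter), which records the arrival of the group that now leaves. The other two steps give context: a 4.3-fold lower number from compound 1 to compound 2 (0.64 log units; beyond the scatter) and a 1.2-fold lower number from compound 1 to compound 3 (0.09 log units; within the scatter). For the measured compounds named here, no measured compound carries the entering ring, so the data give no direct reading of it. A small move towards a lower number is expected, near the edge of the scatter, with compound 2 at 530 nM as the reference without the leaving group. The expected step is a 2.3-fold lower number from compound 3 to compound 4 (0.36 log units; beyond the scatter). The estimate for compound 4 is 800 nM, with an expected range of 280 nM to 2300 nM.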

Compound 4, concentration for 50% growth inhibition: 1990 nM
Estimate against measurement, compound 4: 2.5-fold (0.40 log units) below; low and high end bracket the measured number.
By their numbers in this assay, from the lowest: compound 2; then compounds 3, 4 and 1 (each within the scatter of the next).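

In this assay, replacing the open chain with the ring gives a 1.1-fold higher number from compound 3 to compound 4 (0.03 log units; within the scatter) and no separation, so at this saturated chain carbon bound to an aromatic carbon, 4-methyl-1H-imidazol-1-yl and (2-(dimethylamino)ethyl)(methyl)amino read alike despite one having a five-membered aromatic ring and the other no ring. Compared with hydrogen at the same carbon, the ring gives a 3.8-fold higher number from compound 2 to compound 4 (0.57 log units; beyond the scatter) and the open chain gives a 3.5-fold higher number from compound 2 to compound 3 (0.54 log units; beyond the scatter) beyond the scatter, so both groups shown here go with a higher number than hydrogen, and neither compound 3 nor compound 4 goes against this. The whole (4-methyl-1H-imidazol-1-yl)methyl group gives a 1.2-fold lower number from compound 1 to compound 4 (0.06 log units; within the scatter) and leaves compound 4 level with compound 1, so the separation of compound 2 from compound 1 is absent here.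

No measurement available here explains why the two groups read alike.

The compounds shown leave open whether a smaller group at this carbon, such as a hydroxyl or a primary amine, would stay near compound 2. They also leave open whether a saturated ring such as morpholine or piperazine, or a carboxylic acid, would read like these two groups.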